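Enantiomer pair in the cytotoxicity series: compound 3 to compound 4

The source may hold more compounds than are shown below. What is called first, only, known or untested is meant among the compounds shown, and "the series" means these compounds.

Measured so far in an ADME assay on HEp-2 cells (Homo sapiens) for cytotoxicity, read by MTT assay, with a stated time of 3 days; a lower number here means that less compound is tolerated, a higher number that more compound is tolerated:
- compound 1, `Clc1ccc([C@H](CCn2cncn2)Cc2ccccc2)cc1`, gives 25.7 ug/mL
- compound 2, `Cc1ccc([C@H](CCn2cncn2)Cc2ccccc2)cc1`, gives 152 ug/mL
- compound 3, `C[C@@H](CCn1cncn1)Cc1ccccc1`, gives 131 ug/mL

Compound 3 sits close to compound 2, the two numbers lying within the scatter of each other, and well clear of compound 1, which tolerates markedly less compound. For the measured compounds named here, the only step between measured compounds, a 5.9-fold higher number from compound 1 to compound 2 (0.77 log units; beyond the scatter), concerns a substituent exchange on an aromatic carbon and says nothing about configuration.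

Compound 4, `C[C@H](CCn1cncn1)Cc1ccccc1`, is the next compound. The change from compound 3 is the two compounds have the same atoms and bonds and differ only in configuration as drawn: 1 of 1 stereo elements differ; a stereocentre at a saturated chain carbon is drawn R in compound 3 and S in compound 4. No measured pair in this assay differs only in configuration, so no shown step bears on the change; the data give no ground for a shift in either direction in this assay beyond the scatter.

Compound 4 is therefore expected to lie essentially at the level of compound 3, the estimated step being a 1.0-fold lower number from compound 3 to compound 4 (0.02 log units; within the scatter). The expected value for compound 4 in this assay is 125 ug/mL, with a range from 50 ug/mL to 260 ug/mL.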

Compound 4, half-maximal cytotoxic concentration: 144 ug/mL
For compound 4 the middle estimate is 1.2-fold (0.06 log units) below the measured one; low and high end bracket the measured number.
By their numbers in this assay, from the lowest: compound 1; then compounds 3, 4 and 2 (each within the scatter of the next).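

In this assay, inverting the stereocentre at the saturated chain carbon gives a 1.1-fold higher number from compound 3 to compound 4 (0.04 log units; within the scatter), so neither drawn configuration of this methyl compound can be ranked over the other. The comparison is a clean test of configuration alone: the fact that compounds 3 and 4 differ only in the configuration as drawn

At the same carbon, methyl in place of 4-methylphenyl gives a 1.1-fold lower number from compound 2 to compound 4 (0.02 log units; within the scatter), while methyl in place of 4-chlorophenyl gives a 5.6-fold higher number from compound 1 to compound 4 (0.75 log units; beyond the scatter), so among these three substituents only 4-chlorophenyl stands apart.

On these data alone, whether configuration is equally silent when this carbon carries 4-chlorophenyl or 4-methylphenyl remains open. So does the effect on the number of an amine, a carboxylic acid or a longer chain at this carbon in place of methyl.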